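The source may report more compounds than this note shows. Statements on the series, on what has been measured and on what is new or still open speak of the compounds shown alone.

Of the compounds shown here, three built on one shared core have been measured in a functional assay on MCF7 cells (Homo sapiens) for cytotoxicity, read by MTT assay, with a stated time of 48 h; a lower number here means a stronger inhibitor, a higher number a weaker inhibitor. Compound 1 `Cc1ncc([N+](=O)[O-])n1CCSc1nnc(-c2ccccc2[N+](=O)[O-])o1` gives 18300 nM. Compound 2 `Cc1ncc([N+](=O)[O-])n1CCSc1nnc(-c2ccccc2F)o1` gives 20500 nM, and compound 3 `Cc1ncc([N+](=O)[O-])n1CCSc1nnc(-c2ccc(N(C)C)cc2)o1` gives 14900 nM. The number for compound 2 is the highest of the three as written, yet compound 1, the nearest, and compound 3, the furthest, both lie within the scatter of it, so no real order among the three can be read. Among the measured compounds shown here, the one step between compounds that differ in a single place, a 1.1-fold higher number from compound 1 to compound 2 (0.05 log units; within the scatter), is likewise within the scatter.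

Compound 4 `Cc1ncc([N+](=O)[O-])n1CCSc1nnc(-c2cnccc2N)o1` differs from compound 2 in that same place: 4-aminopyridin-3-yl in place of 2-fluorophenyl on an aromatic carbon. For the measured compounds named here, the step from compound 1 to compound 2 is the only measured step that bears on this change, since it swaps the group on the same aromatic carbon of the core, and it was within the scatter; compounds 1, 2 and 3 carry three different aromatic groups there and all sit within the scatter of one another. For compound 4 in this assay no step beyond the scatter is therefore expected: a 1.2-fold lower number from compound 2 to compound 4 (0.08 log units; within the scatter). Compound 4 is estimated at 17000 nM, with an expected range from 8000 nM to 40000 nM.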

Compound 4, half-maximal inhibitory concentration: 29300 nM
Compound 4: the middle estimate sits 1.7-fold (0.24 log units) below what was measured; the measured number falls inside the stated range.
By their numbers in this assay, from the lowest: compounds 3, 1, 2 and 4 (each within the scatter of the next).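

In this assay, 4-aminopyridin-3-yl in place of 2-fluorophenyl gives a 1.4-fold higher number from compound 2 to compound 4 (0.16 log units; within the scatter). This extends the flat picture at this position to a new kind of group: unlike compounds 1, 2 and 3, which carry rings of carbon only with no hydrogen-bond donor, compound 4 has a ring nitrogen and an amine, and still no step beyond the scatter appears. Nothing shown offers an explanation for this result.

The amine and the ring nitrogen enter together here, so their separate contributions cannot be told apart; a plain pyridin-3-yl or a 4-aminophenyl group would separate them. Also open, going by these compounds, is whether anything at this place moves the number beyond the scatter, such as a carboxylic acid on the phenyl ring or a morpholine in place of the aromatic ring.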